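Replacing the terminal amide amino group with piperidine

A few compounds are considered here, and "the series" means these few. Any claim that something is new, unique, unknown or untested is made for them only; others in the source may bear on it.

Measured so far in a functional assay on HEK293 cells for agonist activity at Vasopressin V2 receptor (Homo sapiens), read by a luciferase reporter and cAMP accumulation; a higher number here means that more compound is needed for the effect, a lower number that less compound is needed:
Compound 1 `Cc1cc(C(=O)N2CCCCc3ccccc32)ccc1CNC(=O)Nc1ccccc1F` gives 30 nM.
Compound 2 `Cc1cc(C(=O)N2CCCCc3ccccc32)ccc1CNC(=O)Nc1ccccc1` gives 130 nM.
Compound 3 `Cc1cc(C(=O)N2CCCCc3ccccc32)ccc1CNC(=O)NCC(N)=O` gives 210 nM.

Compound 3 has the highest number of the three. Its nearest neighbour is reached by a 1.6-fold higher number from compound 2 to compound 3 (0.21 log units; within the scatter), a step within the scatter, while a 7.0-fold higher number from compound 1 to compound 3 (0.85 log units; beyond the scatter) lies beyond it. Compound 4 `Cc1cc(C(=O)N2CCCCc3ccccc32)ccc1CNC(=O)NCC(=O)N1CCCCC1` differs from compound 3 by piperidin-1-yl in place of amino on a carbonyl carbon. Within the data shown here, no measured step exchanges a group at this carbonyl carbon. The closest comparison is a 1.6-fold higher number from compound 2 to compound 3 (0.21 log units; within the scatter), where a wholly different terminal group changed little, whereas a 4.3-fold higher number from compound 1 to compound 2 (0.64 log units; beyond the scatter) shows that a single fluoro can matter. On that basis compound 4 is expected to show a 1.4-fold lower number from compound 3 to compound 4 (0.15 log units; within the scatter), a step not beyond the scatter. The estimate for compound 4 is 150 nM, with a range from 50 nM to 600 nM.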

Compound 4, half-maximal effective concentration: 150 nM
Compound 4: the middle estimate sits on the measured number at the digits printed; the range from low to high includes it.
By their numbers in this assay, from the lowest: compound 1; then compounds 2, 4 and 3 (each within the scatter of the next).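

In this assay, the carbonyl carbon accepts a far bulkier group: piperidin-1-yl brings a six-membered ring and removes the hydrogen-bond donor of amino, yet a 1.4-fold lower number from compound 3 to compound 4 (0.15 log units; within the scatter) stays within the scatter. The full terminal group also sits level with phenyl, with a 1.2-fold higher number from compound 2 to compound 4 (0.06 log units; within the scatter) also within the scatter, whereas a 5.0-fold higher number from compound 1 to compound 4 (0.70 log units; beyond the scatter) lies beyond it, leaving 2-fluorophenyl the better group on the amide-type nitrogen. No measurement here gives a reason for this.

As far as these compounds go, whether a carboxylic acid at this carbonyl carbon, or a longer chain leading up to it, would keep the number in this range remains open.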